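Acrylamide versus dimethylacrylamide on a shared thienopyrimidine-free core

A few compounds are considered here, and "the series" means these few. Any claim that something is new, unique, unknown or untested is made for them only; others in the source may bear on it.

Compound 1 `COc1ccc(Nc2nc(Oc3cccc(NC(=O)C=C(C)C)c3)c3sccc3n2)cc1`: 28800 nM
Compound 2 `COc1cccc(Nc2nc(Oc3cccc(NC(=O)C=C(C)C)c3)c3sccc3n2)c1`: 26100 nM
Compound 3 `C=CC(=O)Nc1cccc(Oc2nc(Nc3cccc(C#N)c3)nc3ccsc23)c1`: 6390 nM

All three compounds were tested in a functional assay on HeLa cells (Homo sapiens) for inhibition, read by MTT assay, with a stated time of 72 h; on this read-out lower numbers stand for stronger inhibition and higher numbers for weaker inhibition. Compound 3 gives the lowest number of the three, and both compound 1 and compound 2 lie beyond the scatter above it. Among the measured compounds shown here, the only measured step, a 1.1-fold lower number from compound 1 to compound 2 (0.04 log units; within the scatter), concerns the methoxyphenyl on the nitrogen and lies within the scatter.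

Compound 4 `CC(C)=CC(=O)Nc1cccc(Oc2nc(Nc3cccc(C#N)c3)nc3ccsc23)c1` is the unmeasured compound. It differs from compound 3 in one place: 2-methylprop-1-en-1-yl in place of vinyl on a carbonyl carbon. For the measured compounds named here, no measured step isolates this change. Compound 1 and compound 2 carry the same 2-methylprop-1-en-1-yl group as compound 4, and both give higher numbers than compound 3, but they also differ from compound 3 in the aryl group on the nitrogen, so their gap to compound 3 cannot be assigned to the carbonyl substituent alone.

With that caution, the step of a 3.1-fold higher number from compound 3 to compound 4 (0.50 log units; beyond the scatter) is expected to run toward a higher number in this assay, of a size comparable to the gap between compound 3 and compound 2. Compound 4 is therefore estimated at 20000 nM, with a range from 6000 nM to 60000 nM.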

Compound 4, half-maximal inhibitory concentration: 19800 nM
Estimate against measurement, compound 4: 1.0-fold (0.00 log units) above; the measured number falls inside the stated range.
By their numbers in this assay, from the lowest: compound 3; then compounds 4, 2 and 1 (each within the scatter of the next).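

With the rest of the molecule held constant, this assay now isolates the change at the carbonyl carbon: 2-methylprop-1-en-1-yl in place of vinyl gives [ a 3.1-fold higher number from compound 3 to compound 4 (0.49 log units; beyond the scatter) ]. With the 2-methylprop-1-en-1-yl group kept, changing the aryl group on the nitrogen produces no difference that can be told apart from ordinary assay variation, with cyano in place of methoxy giving [ a 1.3-fold lower number from compound 2 to compound 4 (0.12 log units; within the scatter) ] and 3-cyanophenyl in place of 4-methoxyphenyl giving [ a 1.5-fold lower number from compound 1 to compound 4 (0.16 log units; within the scatter) ]. Among these four compounds, the substituent on the carbonyl carbon is therefore the only place where a single change moves the number beyond the scatter, while the aryl changes tested alongside the 2-methylprop-1-en-1-yl group do not.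

The data shown offer no measurement that explains this step. From the compounds shown here alone, it remains open whether the same step would recur with a methoxyphenyl group on the nitrogen, and how a saturated ethyl group, or a vinyl group carrying a dimethylamine, would read on the same carbonyl carbon.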